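The source may hold more compounds than are shown below. What is called first, only, known or untested is meant among the compounds shown, and "the series" means these compounds.

Measured compounds so far:
compound 1 `Cn1nc(-c2ccccc2)c2cc(C(=N)Nc3ccccc3)ncc21` gives 17300 nM in a functional assay on PC-3 cells (Homo sapiens) for cytotoxicity, read by MTT assay, with a stated time of 72 h; on this read-out lower numbers stand for stronger inhibition and higher numbers for weaker inhibition
compound 2 `COc1ccc(Cn2nc(-c3ccccc3)c3cc(C(=N)Nc4ccccc4)ncc32)cc1` gives 6300 nM in this assay
compound 3 `Cn1nc(-c2ccccc2)c2cc(C(=N)Nc3cccc(C(F)(F)F)c3)ncc21` gives 20900 nM in this assay

Compound 2 differs from compound 1 by a single change, (4-methoxyphenyl in place of hydrogen on a saturated chain carbon bound to an aromatic nitrogen). In this assay this change made a 2.7-fold lower number from compound 1 to compound 2 (0.44 log units; beyond the scatter). Compound 3 differs from compound 1 in another way, (trifluoromethyl in place of hydrogen on an aromatic carbon), and this made a 1.2-fold higher number from compound 1 to compound 3 (0.08 log units; within the scatter), so compound 3 and compound 1 cannot be told apart on this read-out.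

Compound 4 `COc1ccc(Cn2nc(-c3ccccc3)c3cc(C(=N)Nc4cccc(C(F)(F)F)c4)ncc32)cc1` has not been measured. It differs from compound 3 by 4-methoxyphenyl in place of hydrogen on a saturated chain carbon bound to an aromatic nitrogen. For the measured compounds named here, this is the same change, at the same place, as the one from compound 1 to compound 2; the two pairs differ only in what the rest of the molecule carries, and that difference is the one described for compound 1 and compound 3.

Going by the values given here, for compound 4 in this assay a step of about the earlier size is expected, a 2.7-fold lower number from compound 3 to compound 4 (0.43 log units; beyond the scatter), because a 2.7-fold lower number from compound 1 to compound 2 (0.44 log units; beyond the scatter) is the only direct example of this change and because a 1.2-fold higher number from compound 1 to compound 3 (0.08 log units; within the scatter) shows that compound 3 starts close to where compound 1 started. With one example to go on, the range is kept wide. Compound 4 is therefore estimated at 7700 nM, expected to fall between 3500 nM and 17000 nM.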

Compound 4, half-maximal inhibitory concentration: > 50000 nM
Compound 4 was reported as a limit; the forecaster's own chance of this, stated with the estimate: 5%; at least 6.4-fold (0.81 log units) between middle value and limit.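

In this assay compound 4 gives > 50000 nM, which is a limit of the assay and not a number: the limit of > 50000 nM in this assay, at which 1 of the 4 values shown sits.

Changing methyl to 4-methoxybenzyl lowered the number on the core of compound 1, but with trifluoromethyl present the same change gave an at least 2.3-fold higher number from compound 3 to compound 4 (0.37 log units; beyond the scatter), so neither its size nor its direction carried over from one core to the other: the same change on two cores in this assay, a 2.7-fold lower number (0.44 log units; beyond the scatter) from compound 1 to compound 2 and an at least 2.3-fold higher number (0.37 log units; beyond the scatter) from compound 3 to compound 4, at least 6.5-fold (0.81 log units) apart, beyond the scatter of two such steps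

Read the other way, trifluoromethyl left the number within the usual scatter on the methyl compounds, yet it gave an at least 7.9-fold higher number from compound 2 to compound 4 (0.89 log units; beyond the scatter) on the 4-methoxybenzyl compounds, so its effect also depends on the rest of the molecule: the same change on two cores in this assay, a 1.2-fold higher number (0.08 log units; within the scatter) from compound 1 to compound 3 and an at least 7.9-fold higher number (0.89 log units; beyond the scatter) from compound 2 to compound 4, at least 6.5-fold (0.81 log units) apart, beyond the scatter of two such steps

This single set of four compounds shows that the two changes do not simply add up here, but it does not show why, nor whether the same would hold for any other pair of groups.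

Going by these compounds, it remains open whether this reversal is tied to trifluoromethyl, or whether a chlorine or a nitrile in its place would behave the same way. On these data alone, it is equally open whether a plain benzyl group or a longer saturated chain would follow the 4-methoxybenzyl compounds.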